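The compounds below may be only part of what the source reports. "The series", "measured", "known", "first", "only" and "open" are said of these compounds alone.

The three measured compounds share one core and differ only in the group on the aniline ring. Compound 1 `Fc1cccc(-c2nc(Nc3ccccc3)c3cc(F)ccc3n2)c1` gives 48300 nM in a functional assay on HL-60 cells (Homo sapiens) for cytotoxicity, read by MTT assay, with a stated time of 48 h; a higher number here means a weaker inhibitor, a lower number a stronger inhibitor. Compound 2 `Fc1cccc(-c2nc(Nc3ccc(Br)cc3)c3cc(F)ccc3n2)c1` carries bromo in place of hydrogen on an aromatic carbon, and in this assay compound 2 reaches only a limit of the assay, > 50000 nM. Compound 3 `Oc1ccc(Nc2nc(-c3cccc(F)c3)nc3ccc(F)cc23)cc1` carries hydroxy in place of hydrogen on an aromatic carbon, and in this assay compound 3 likewise reaches only a limit, > 50000 nM. Compound 3 therefore stands at the point where (the limit of > 50000 nM in this assay, at which 2 of the 3 values shown sit). The measured steps are an at least 1.0-fold higher number from compound 1 to compound 3 (0.01 log units; that floor lies within the scatter) and an at least 1.0-fold higher number from compound 1 to compound 2 (0.01 log units; that floor lies within the scatter), while a step that the two limits leave unreadable from compound 2 to compound 3.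

Compound 4 `Oc1ccccc1Nc1nc(-c2cccc(F)c2)nc2ccc(F)cc12` is not yet measured. It differs from compound 3 by 2-hydroxyphenyl in place of 4-hydroxyphenyl on a nitrogen on an aromatic ring. Going by the values given here, none of the measured steps moves a hydroxy group around its ring; both steps from compound 1 end at the limit, and the step between compound 2 and compound 3 cannot be read. Nothing in these numbers suggests that the moved hydroxy group would bring the value off the limit. For compound 4 the expected step is a number no higher from compound 3 to compound 4 (the limit leaves the size open). Compound 4 is thus estimated at 50000 nM, within a range from 15000 nM to 150000 nM.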

Compound 4, half-maximal inhibitory concentration: 44400 nM
The estimate for compound 4 lay 1.1-fold (0.05 log units) above the measured number; the measured number falls inside the stated range.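

Moving the hydroxy group from the 4-hydroxyphenyl to the 2-hydroxyphenyl form on the nitrogen gives a real number in this assay where compound 3 gave only a limit, and the step reads an at least 1.1-fold lower number from compound 3 to compound 4 (0.05 log units; that floor lies within the scatter); the comparison with the bromo compound has the same shape, an at least 1.1-fold lower number from compound 2 to compound 4 (0.05 log units; that floor lies within the scatter), so both steps give only a floor that cannot be told from scatter. Set against the plain phenyl group of compound 1, the 2-hydroxyphenyl group gives a 1.1-fold lower number from compound 1 to compound 4 (0.04 log units; within the scatter), which means that these two compounds cannot be told apart in this assay. Compound 2 and compound 3 remain limits, not numbers: the limit of > 50000 nM in this assay, at which 2 of the 4 values shown sit.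

As far as these compounds go, how far compound 2 and compound 3 really lie from compound 4 stays open, and the step between compound 2 and compound 3 cannot be read. Also open, from the compounds shown here alone, is whether a methoxy group, an amine or a carboxylic acid on this same ring would give a number clearly apart from that of compound 1.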